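Terminal aryl exchange on the shared core

This account rests on a few compounds, and the source may have more. Where it says the series, first, only, none or still open, it means among the compounds named here.

The series shares the core of compound 1 `COc1cc2cc(Oc3ccc(NC(=O)Nc4ccc(C)cc4)cc3)c(C)nc2cc1OC`, with the aryl group on the amide-type nitrogen as the point of variation. For the measured compounds named here, in a functional assay on ACHN cells (Homo sapiens) for inhibition, read by sulforhodamine B assay, with a stated time of 48 h, tested at 10 uM (a higher number here means a weaker effect of the compound at the concentration tested, a lower number a stronger effect), compound 1 gives 103%, the highest of the two numbers measured so far. Compound 2 `COc1cc2cc(Oc3ccc(NC(=O)Nc4ccc(Cl)c(C(F)(F)F)c4)cc3)c(C)nc2cc1OC` gives 13.6% in this assay, and the step of a number 89.4 percentage points lower from compound 1 to compound 2 (beyond the scatter) shows that exchanging this aryl group moves the read-out far beyond the scatter. Compound 3 `COc1cc2cc(Oc3ccc(NC(=O)Nc4ccc(Cl)c(Cl)c4)cc3)c(C)nc2cc1OC` is not yet measured; it differs from compound 1 by 3,4-dichlorophenyl in place of 4-methylphenyl on an amide-type nitrogen. Going by the values given here, the only measured step bearing on this change is a number 89.4 percentage points lower from compound 1 to compound 2 (beyond the scatter), which replaces the same 4-methylphenyl with another substituted phenyl and is large. A downward step of broadly similar size is therefore expected, though no second measurement anchors the 3,4-dichlorophenyl group, so the range is wide. For compound 3 the expected value in this assay is 25%, between 5% and 65%. This corresponds to an expected step of a number 78 percentage points lower from compound 1 to compound 3 (beyond the scatter).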

Compound 3, a percentage reported as activity, at one concentration (the size of the read-out at that concentration, not a potency): 16.4%
Estimate against measurement, compound 3: 8.6 percentage points above; the measured number falls inside the stated range.
By their numbers in this assay, from the lowest: compounds 2 and 3 (each within the scatter of the next); then compound 1.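

In this assay the large drop is no longer tied to a single group: the step of a number 86.6 percentage points lower from compound 1 to compound 3 (beyond the scatter) shows that 3,4-dichlorophenyl in place of 4-methylphenyl on the amide-type nitrogen also brings the read-out far down. Chloro in place of trifluoromethyl on an aromatic carbon gives the step of a number 2.8 percentage points higher from compound 2 to compound 3 (within the scatter) and so separates compounds 2 and 3 by no more than the usual scatter. No measurement at hand explains either step.

From the compounds shown here alone, whether an unsubstituted phenyl, a phenyl bearing an amine or a carboxylic acid, or a pyridine ring on this nitrogen would give a low or a high read-out remains open. Going by these compounds, the read-out comes from one concentration, so any difference in potency between compound 2 and compound 3 also remains open.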